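This account rests on a few compounds, and the source may have more. Where it says the series, first, only, none or still open, it means among the compounds named here.

Among the measured compounds shown here, only two compounds have been read so far in an ADME assay (liver) for metabolic stability, with Liver microsome (Rattus norvegicus) as the target, using microsomes and NADPH, with a stated time of 30 min, at 37 degrees C, tested at 1 uM (on this read-out higher numbers stand for fast clearance and lower numbers for slow clearance), and neither gives a number. Compound 1 `CC(O)(c1ccc(-c2ccc(S(=O)(=O)c3ccc(N)nc3)cn2)nc1)C(F)(F)F` returns < 14 mL.min-1.g-1, which is a limit of the assay. Compound 2 `COc1cc(C(O)(C(F)(F)F)C(F)(F)F)cnc1-c1ccc(S(=O)(=O)c2ccc(N)nc2)cc1` returns < 14 mL.min-1.g-1, also a limit and not a number. The whole picture so far is therefore (the limit of < 14 mL.min-1.g-1 in this assay, at which 2 of the 2 values shown sit).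

Compound 3 `CC(C)(O)C#Cc1cc(C(O)(C(F)(F)F)C(F)(F)F)cnc1-c1ccc(S(=O)(=O)c2ccc(N)nc2)cc1` keeps the core of compound 2 but carries 3-hydroxy-3-methylbut-1-yn-1-yl in place of methoxy on an aromatic carbon, ortho to a large group and two atoms from the ring nitrogen: 3-hydroxy-3-methylbut-1-yn-1-yl in place of methoxy on an aromatic carbon. For the measured compounds named here, no measured pair shows what an exchange of this kind does in this assay, so the expectation starts from compound 2 alone, whose < 14 mL.min-1.g-1 is a limit. The expected change, an at least 1.0-fold higher number from compound 2 to compound 3 (0.02 log units; that floor lies within the scatter), is small, towards faster clearance if it shows at all, and it is not expected to go clearly beyond the usual scatter. For compound 3 the estimated value is 15 mL.min-1.g-1, with an expected range from 7 mL.min-1.g-1 to 35 mL.min-1.g-1.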

Compound 3, intrinsic clearance in microsomes: < 14 mL.min-1.g-1
Compound 3: a limit, no number; the forecaster's own chance of this, stated with the estimate: 50%; middle value at least 1.0-fold (0.02 log units) away from the limit.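

In this assay compound 3 gives < 14 mL.min-1.g-1 and this is a limit of the assay, not a number. Compound 2 also stands at a limit, so no step can be read between compound 2 and compound 3. The compounds shown leave open whether their clearances differ at all, and what the exchange of methoxy for 3-hydroxy-3-methylbut-1-yn-1-yl does to clearance, with every value at the same place: the limit of < 14 mL.min-1.g-1 in this assay, at which 3 of the 3 values shown sit.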